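Swapping a pyridine for a thiadiazole on a bombesin receptor agonist

The compounds below may be only part of what the source reports. "The series", "measured", "known", "first", "only" and "open" are said of these compounds alone.

Measured so far:
- compound 1, `CCC(C)(C)Cc1c[nH]c(CCc2ccc(-c3cccc(N)n3)cc2)n1`: 37 nM
- compound 2, `CCC(C)(C)Cc1c[nH]c(CCc2ccc(-c3ccncc3)cc2)n1`: 305 nM
- compound 3, `c1ccc(-c2ccc(CCc3nc(CC4CCCC4)c[nH]3)cc2)nc1`: 425 nM

All three share a core that carries a distal aromatic ring, and they were tested in a functional assay on HEK293 cells for agonist activity at Bombesin receptor subtype-3 (Homo sapiens), read by luminescence and calcium flux, with a stated time of 10 min; a higher number here means that more compound is needed for the effect, a lower number that less compound is needed. Compound 2 and compound 3 give numbers that lie within the usual scatter of each other, so they cannot be told apart on this evidence. Compound 1 stands clearly apart: the step of an 8.2-fold higher number from compound 1 to compound 2 (0.92 log units; beyond the scatter) shows that exchanging the 6-aminopyridin-2-yl group for pyridin-4-yl costs a modest but real amount of potency.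

Compound 4, `CCC(C)(C)Cc1c[nH]c(CCc2ccc(-c3csnn3)cc2)n1`, has not yet been measured. It differs from compound 2 only at the distal ring: 1,2,3-thiadiazol-4-yl in place of pyridin-4-yl on an aromatic carbon. Among the measured compounds shown here, no measured step addresses a change of this kind. For the measured compounds named here, the only step on record concerns the same position, an 8.2-fold higher number from compound 1 to compound 2 (0.92 log units; beyond the scatter), and it shows that this part of the molecule can matter; however, it replaced one six-membered ring with another, whereas here a five-membered ring with three hetero atoms enters.

Going by the values given here, with no direct precedent, the expectation for compound 4 is a number close to that of compound 2, with a wide range on either side; the estimated step of a 1.3-fold higher number from compound 2 to compound 4 (0.12 log units; within the scatter) is small relative to the scatter. Compound 4 is therefore estimated at 400 nM, expected to fall between 120 nM and 1500 nM.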

Compound 4, half-maximal effective concentration: 538 nM
The estimate for compound 4 lay 1.3-fold (0.13 log units) below the measured number; measured number inside the range.
By their numbers in this assay, from the lowest: compound 1; then compounds 2, 3 and 4 (each within the scatter of the next).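

Replacing the six-membered pyridin-4-yl with the five-membered 1,2,3-thiadiazol-4-yl, which brings in sulfur and has more hetero atoms in its ring, gives a 1.8-fold higher number from compound 2 to compound 4 (0.25 log units; within the scatter). In this assay, compound 2 and compound 4 therefore cannot be told apart, so at this position these two rings of different size and make-up perform alike. The 6-aminopyridin-2-yl group still stands clearly apart, with a 15-fold higher number from compound 1 to compound 4 (1.16 log units; beyond the scatter), though nothing available explains either of these results.

Going by these compounds, what sets compound 1 apart remains open, since its ring differs from those of compound 2 and compound 4 in more than the amine, and compound 3, which carries a plain pyridine ring, also has a different side chain on the shared core. A pyridin-2-yl group paired with the side chain of compound 1 would help separate the amine from the ring itself, and an amine placed on the 1,2,3-thiadiazol-4-yl ring would test whether that group can bring a similar gain on a five-membered ring.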